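Capping a Hydroxy Group: From Compound 2 to Compound 4

The source may hold more compounds than are shown below. What is called first, only, known or untested is meant among the compounds shown, and "the series" means these compounds.

Of the compounds shown here, three sharing one core have been tested in a functional assay on HOP-62 cells (Homo sapiens) for inhibition, read by sulforhodamine B assay, with a stated time of 48 h, tested at 1 uM; a lower number here means a stronger effect, a higher number a weaker effect of the compound at the concentration tested. Compound 1 `O=C(Nc1cccc(-n2cc(-c3ccncc3)c(-c3cc(O)cc(Cl)c3)n2)c1)Nc1ccc(Cl)c(C(F)(F)F)c1` gives 96%, and compound 2 `O=C(Nc1cccc(-n2cc(-c3ccncc3)c(-c3cc(O)cc(Cl)c3)n2)c1)Nc1ccc(Cl)c(Cl)c1` gives 97%, with the step between them, a number 1 percentage points higher from compound 1 to compound 2 (within the scatter), lying within the scatter. Compound 3 `COc1cc(Cl)cc(-c2nn(-c3cccc(NC(=O)Nc4cc(C(F)(F)F)cc(C(F)(F)F)c4)c3)cc2-c2ccncc2)c1` differs from compound 2 in two places. In this assay compound 3 gives 40%. Compound 2 thus sits at the high end of the numbers seen, indistinguishable from compound 1 and far from compound 3.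

Compound 4 `COc1cc(Cl)cc(-c2nn(-c3cccc(NC(=O)Nc4ccc(Cl)c(Cl)c4)c3)cc2-c2ccncc2)c1` is the next step from compound 2: methyl in place of hydrogen on an oxygen on an aromatic ring. Among the measured compounds shown here, no measured step isolates this change. For the measured compounds named here, the only step on record, a number 1 percentage points higher from compound 1 to compound 2 (within the scatter), concerns a different part of the molecule and was within the scatter. Compound 3 carries the same methoxy group as compound 4 but also a different substitution on the distant ring, so its gap to compound 2 cannot be assigned to the methyl alone. Given that compound 3 gives 40%, a drop is the more likely outcome, but with wide uncertainty. The step of a number 32 percentage points lower from compound 2 to compound 4 (beyond the scatter) is the expected result. Compound 4 is estimated at 65%, within a range from 35% to 95%.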

Compound 4, a percentage reported as activity, at one concentration (the size of the read-out at that concentration, not a potency): 91%
For compound 4 the middle estimate is 26 percentage points below the measured one; low and high end bracket the measured number.
By their numbers in this assay, from the lowest: compound 3; then compounds 4, 1 and 2 (each within the scatter of the next).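

In this assay, the first direct test of this change gives a number 6 percentage points lower from compound 2 to compound 4 (within the scatter), so swapping 3-chloro-5-hydroxyphenyl for 3-chloro-5-methoxyphenyl leaves no measurable mark on the read-out at the single concentration tested. The methoxy group alone therefore does not go with a low number: compound 4 gives 91% with it, while compound 3, which carries the same group alongside a different substitution on the distant ring, gives 40%. Nothing available explains why capping this oxygen with methyl makes so little difference.

Going by these compounds, it remains open whether a longer chain on this oxygen, such as ethyl or propyl, would also leave the number unchanged. An amine or a carboxylic acid in place of the hydroxy group at this position is equally untested by the compounds shown here.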